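Ethyl to Benzyl Ester Change and Cell Toxicity

This account rests on a few compounds, and the source may have more. Where it says the series, first, only, none or still open, it means among the compounds named here.

Compound 1 `C=C[C@@](C)(/C=C/c1ccc(O)cc1)CC/C=C/C(=O)OCC` was tested in an ADME assay on BJ cells (Homo sapiens) for cytotoxicity, with a stated time of 72 h (on this read-out lower numbers stand for an effect already at smaller amounts and higher numbers for an effect only at larger amounts of compound), and the value recorded for compound 1, > 36600 nM, is a limit of the assay. Compound 2 `C=C[C@@](C)(/C=C/c1ccc(O)cc1)CC/C=C/C(=O)OCc1ccccc1` differs from compound 1 by phenyl in place of methyl on a saturated chain carbon bound to an oxygen next to a carbonyl group. In this assay compound 2 also reaches only a limit, > 36600 nM. The step that the two limits leave unreadable from compound 1 to compound 2 is therefore not sizable. Compound 3 `C=C[C@@](C)(/C=C/c1ccc(O)c(/C=C/C(=O)OCC)c1)CCC=C(C)C` rests on another core; the difference between the core of compound 1 and the core of compound 3 is not broken down here. In this assay compound 3 gives a limit as well, > 36600 nM. Compound 4 `C=C[C@@](C)(/C=C/c1ccc(O)c(/C=C/C(=O)OCc2ccccc2)c1)CCC=C(C)C` is compound 3 with phenyl in place of methyl on a saturated chain carbon bound to an oxygen next to a carbonyl group, the same change as from compound 1 to compound 2. Because every value sits at the limit of > 36600 nM in this assay, at which 3 of the 3 values shown sit, the expected step is a step that the limit leaves unreadable from compound 3 to compound 4. Compound 4 is estimated at 60000 nM, between 36600 nM and 150000 nM, most likely again only a limit.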

Compound 4, half-maximal effective concentration: > 36600 nM
Compound 4: a limit, no number; the forecaster's own chance of this, stated with the estimate: 85%; the middle value does not contradict the limit.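

No step can be read from compound 3 to compound 4, since both give only a limit in this assay: the limit of > 36600 nM in this assay, at which 4 of the 4 values shown sit. The compounds shown leave open whether ethyl to benzyl changes cytotoxicity at all, and at what concentration any of them would act.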